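Hexyloxy Replacing Dimethylpiperidinyl Next to the Ring Nitrogen

The source may hold more compounds than are shown below. What is called first, only, known or untested is meant among the compounds shown, and "the series" means these compounds.

Compound 3 `CC1CC(C)CN(c2nc(C(F)(F)Cl)ccc2CNC(=O)C(C)c2ccc(NS(C)(=O)=O)c(F)c2)C1` gives 1 nM in an assay on CHO cells for antagonist activity at transient receptor potential cation channel subfamily V member 1 (Homo sapiens), read by FLIPR (a higher number here means a weaker inhibitor, a lower number a stronger inhibitor), level with compound 1 `CC1CCN(c2nc(C(F)F)ccc2CNC(=O)C(C)c2ccc(NS(C)(=O)=O)c(F)c2)CC1`, which gives 1 nM; compound 2 `CC1CCN(c2nc(-c3ccc(F)cc3)ccc2CNC(=O)C(C)c2ccc(NS(C)(=O)=O)c(F)c2)CC1` gives 59 nM, and the step of a 59-fold higher number from compound 1 to compound 2 (1.77 log units; beyond the scatter) came from 4-fluorophenyl in place of difluoromethyl on an aromatic carbon. Compound 4 `CCCCCCOc1nc(C(F)(F)Cl)ccc1CNC(=O)C(C)c1ccc(NS(C)(=O)=O)c(F)c1` differs from compound 3 elsewhere: hexyloxy in place of 3,5-dimethylpiperidin-1-yl on an aromatic carbon, on an aromatic carbon of the six-membered aromatic ring with one nitrogen, next to the ring nitrogen. No measured step touches this position, so the one step shown offers little direct guidance. Compound 1 and compound 3, which differ in more than one place, sit level. On these data alone, a chain in place of the ring is untested, so a modest loss is expected, a step of a 5.0-fold higher number from compound 3 to compound 4 (0.70 log units; beyond the scatter). Compound 4 is estimated at 5 nM, ranging from 1 nM to 30 nM.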

Compound 4, inhibition constant: 0.8 nM
Beside the measured number, compound 4's estimate is 6.3-fold (0.80 log units) above it; measured number below the stated range.
By their numbers in this assay, from the lowest: compounds 4, 1 and 3 (each within the scatter of the next); then compound 2.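

At this position, on an aromatic carbon next to the ring nitrogen, the ring of 3,5-dimethylpiperidin-1-yl is not needed in this assay: hexyloxy takes its place with a 1.3-fold lower number from compound 3 to compound 4 (0.10 log units; within the scatter), so the open chain and the ring cannot be told apart here. The attachment can also pass from the ring's nitrogen to the oxygen of hexyloxy without a change beyond the scatter. No evidence here explains why the two groups sit level. The compounds shown leave open whether a shorter butoxy chain, a longer octyloxy chain or a hexylamino group would also hold level.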